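A few compounds are considered here, and "the series" means these few. Any claim that something is new, unique, unknown or untested is made for them only; others in the source may bear on it.

Of the compounds shown here, three in this set have been measured in a physicochemical assay for lipophilicity, measured as octanol-water partition; a higher number here means a more lipophilic compound, a lower number a more polar compound. Compound 1 `COC(=O)c1cn(C/C=C(\C)CCC=C(C)C)nn1` gives 3.2, compound 2 `CCCc1cn(C/C=C(/C)CC/C=C(\C)CCC=C(C)C)nn1` gives 6.5, and compound 3 `CCCCCc1cn(C/C=C(\C)CC/C=C(\C)CCC=C(C)C)nn1` gives 7.5. Compound 3 thus stands highest of the three: compound 2 is nearest, a step below it that lies beyond the scatter, and compound 1 is furthest, far below it. Compound 4 `CCCc1cn(C/C=C(\C)CC/C=C(\C)CCC=C(C)C)nn1` has not yet been measured. It differs from compound 3 in one place: hydrogen in place of ethyl on a saturated chain carbon, three bonds along the chain from an aromatic carbon. Among the measured compounds shown here, no step between measured compounds isolates this change, yet compound 2, with 6.5, carries the same propyl group that compound 4 carries. The step from compound 3 to compound 4 is therefore expected to be downward, a number 1.00 log units lower from compound 3 to compound 4 (beyond the scatter). On this basis compound 4 is estimated at 6.5, within the range 6 to 7.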

Compound 4, partition coefficient: 6.5
Compound 4: the middle estimate sits on the measured number at the digits printed; measured number inside the range.
By their numbers in this assay, from the lowest: compound 1; then compounds 2 and 4 (each within the scatter of the next); then compound 3.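

In this assay the change from pentyl to propyl on the chain now has a step of its own, with a number 1.00 log units lower from compound 3 to compound 4 (beyond the scatter) as the reading for this change alone. The drawn configuration of the double bond gives no change at the digits printed from compound 2 to compound 4 (within the scatter) and so does not separate the two compounds in this read-out. That pair isolates configuration alone: the fact that compounds 2 and 4 differ only in the configuration as drawn. The compounds shown leave open whether a chain longer than pentyl would extend this step. They also leave open how an amine or a carboxylic acid at this place would read.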